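This account rests on a few compounds, and the source may have more. Where it says the series, first, only, none or still open, it means among the compounds named here.

Measured in an ADME assay on the whole organism (Rattus norvegicus) for pharmacokinetics, at a dose of 1 mg/kg by the intravenous route; on this read-out lower numbers stand for narrower distribution and higher numbers for wider distribution into tissues:
compound 1 `O=C(c1cn[nH]c1)N1CCC(C(=O)N2N=CCC2c2ccccc2)CC1`: 1.6 L/kg
compound 2 `O=C(c1c[nH]nn1)N1CCC(C(=O)N2N=CCC2c2ccccc2)CC1`: 1.3 L/kg
compound 3 `N#Cc1cc(N2CCC(C(=O)N3N=CC[C@H]3c3cc(F)cc(F)c3)CC2)ncn1`: 4.6 L/kg

Compound 2 stands at 1.3 L/kg, within the scatter of compound 1 and well under the number for compound 3. Compound 4 `O=C(c1cocn1)N1CCC(C(=O)N2N=CCC2c2ccccc2)CC1` changes one group of compound 2: 1,3-oxazol-4-yl in place of 1H-1,2,3-triazol-4-yl on a carbonyl carbon. In words, 1,3-oxazol-4-yl sits in place of 1H-1,2,3-triazol-4-yl on a carbonyl carbon. Going by the values given here, the one measured step that bears on this also swaps the ring group on that carbonyl: a 1.2-fold lower number from compound 1 to compound 2 (0.09 log units; within the scatter). Among the compounds with values here, no measured compound carries the 1,3-oxazol-4-yl group, so this guide is thin. The change expected in this assay is therefore none beyond the scatter: a 1.2-fold higher number from compound 2 to compound 4 (0.06 log units; within the scatter). For compound 4 the estimated value is 1.5 L/kg, with an expected range of 0.8 L/kg to 2.8 L/kg.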

Compound 4, volume of distribution at steady state: 0.98 L/kg
For compound 4 the middle estimate is 1.5-fold (0.18 log units) above the measured one; measured number inside the range.
By their numbers in this assay, from the lowest: compounds 4, 2 and 1 (each within the scatter of the next); then compound 3.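

In this assay, the carbonyl position also accepts 1,3-oxazol-4-yl, a ring with 0 hydrogen-bond donors, and both new steps stay small (a 1.3-fold lower number from compound 2 to compound 4 (0.12 log units; within the scatter); a 1.6-fold lower number from compound 1 to compound 4 (0.21 log units; within the scatter)). Compound 1, compound 2 and compound 4 therefore cannot be told apart here, so replacing 1H-1,2,3-triazol-4-yl, with its 1 donor, gives no shift beyond the scatter. Nothing available explains these numbers.

All three groups are five-membered aromatic rings, so an amine or a longer alkyl chain on that carbonyl remains an open case.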